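Two Limits and an Acetyl Question

The source may report more compounds than this note shows. Statements on the series, on what has been measured and on what is new or still open speak of the compounds shown alone.

In an ADME assay on HEK293 cells (Homo sapiens) for cytotoxicity, with a stated time of 72 h (a higher number here means that more compound is needed for the effect, a lower number that less compound is needed), compound 1 (`COc1ccc(/C=C/[C@@](C)(/C=C/c2ccc(O)c(/C=C/C#N)c2)CCC=C(C)C)cc1`) gives > 36600 nM, which is a limit and not a number. Compound 2 (`COc1ccc(/C=C/[C@@](C)(/C=C/c2ccc(O)c(/C=C/C(=O)OC(C)(C)C)c2)CCC=C(C)C)cc1`) gives > 36600 nM, which is likewise a limit. Compound 2 therefore has no exact position, and the record so far is the limit of > 36600 nM in this assay, at which 2 of the 2 values shown sit.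

Compound 3 (`COc1ccc(/C=C/[C@@](C)(/C=C/c2ccc(O)c(/C=C/C(C)=O)c2)CCC=C(C)C)cc1`) keeps the core of compound 2 and carries methyl in place of tert-butoxy on a carbonyl carbon, turning tert-butoxycarbonyl into acetyl: methyl in place of tert-butoxy on a carbonyl carbon.

For the measured compounds named here, the one measured step that bears on this change is a step that the two limits leave unreadable from compound 1 to compound 2. It also alters the same chain, with tert-butoxycarbonyl in place of cyano, but it offers no size to carry forward. Neither compound yielded a number in this assay, so no step beyond the scatter is expected, and no direction can be assigned. Compound 3 may well be reported only as a limit too. The step expected is a step that the limit leaves unreadable from compound 2 to compound 3. For compound 3 the estimated value is 40000 nM, with an expected range from 15000 nM to 80000 nM.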

Compound 3, half-maximal effective concentration: 14600 nM
For compound 3 the middle estimate is 2.7-fold (0.44 log units) above the measured one; the whole stated range lies above it.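

For the compounds shown here, this is the first number on this chain, and it shows that the group on the carbonyl carbon matters in this assay: methyl in place of tert-butoxy gives an at least 2.5-fold lower number from compound 2 to compound 3 (0.39 log units; beyond the scatter), and acetyl in place of cyano on the double-bonded chain carbon gives an at least 2.5-fold lower number from compound 1 to compound 3 (0.39 log units; beyond the scatter). Both steps are minimum sizes, and the result shows that acetyl differs from both tert-butoxycarbonyl and cyano, while the step between those two cannot be read. Compound 1 and compound 2 both remain at a limit, so acetyl alone stands apart from the other two groups: the limit of > 36600 nM in this assay, at which 2 of the 3 values shown sit.

The compounds shown leave open how large the two steps really are, and whether the lower number follows from methyl itself or from the loss of the ester oxygen that goes with tert-butoxy. An ethyl ketone, a methyl ester, a carboxylic acid or a primary amide on the same carbonyl carbon would separate these readings, and a longer chain in place of methyl would show how far the acetyl result extends.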